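A few compounds are considered here, and "the series" means these few. Any claim that something is new, unique, unknown or untested is made for them only; others in the source may bear on it.

Working notes on the series. In a functional assay on CHO cells for agonist activity at G-protein coupled receptor 39 (Homo sapiens), read by calcium flux (on this read-out lower numbers stand for smaller maximal responses and higher numbers for larger maximal responses), compound 1 `Cc1cc(NCc2ccc(F)cc2)n2ncc(-c3ccccn3)c2n1` gives 57%, the higher of the two numbers measured; compound 2 `N#Cc1ccc(N2CCN(Cc3cn4cc(Cl)ccc4n3)CC2)nc1` gives 48% in this assay, a gap that lies within the scatter, so the two stand together. Compound 3 `CNC(=O)C(Nc1cc(C)nc2c(-c3ccccn3)cnn12)c1ccc(F)cc1` is not yet measured. It differs from compound 1 by methylcarbamoyl in place of hydrogen on a saturated chain carbon bound to an aromatic carbon and a nitrogen on an aromatic ring. Among the measured compounds shown here, no step between measured compounds bears on this change, so the expectation rests on compound 1 alone. The step from compound 1 to compound 3 is expected to stay within the scatter, a number 5 percentage points lower from compound 1 to compound 3 (within the scatter). For compound 3 an estimate of 52% in this assay is expected, in the range 32% to 72%.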

Compound 3, largest response reached (Emax), in percent of the reference or control that the assay uses: 75%
The estimate for compound 3 lay 23 percentage points below the measured number; the whole stated range lies below it.
By their numbers in this assay, from the lowest: compounds 2 and 1 (each within the scatter of the next); then compound 3.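

Methylcarbamoyl in place of hydrogen on the saturated chain carbon bound to an aromatic carbon and a nitrogen on an aromatic ring gives, in this assay, a number 18 percentage points higher from compound 1 to compound 3 (beyond the scatter). Among the compounds shown here, this position therefore accepts a group of 4 heavy atoms with a larger maximal response, which no earlier step could show. No measured evidence bears on the origin of this rise. From the compounds shown here alone, whether the amide is needed or any group here would serve stays open: a methyl group, a carboxylic acid or a dimethylcarbamoyl group on this carbon would separate these readings.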